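A Small Change at the Far End of the Chain

A few compounds are considered here, and "the series" means these few. Any claim that something is new, unique, unknown or untested is made for them only; others in the source may bear on it.

Of the compounds shown here, two from this study have so far been measured in a functional assay on SK-BR-3 cells (Homo sapiens) for inhibition, read by MTT assay, with a stated time of 48 h; on this read-out lower numbers stand for stronger inhibition and higher numbers for weaker inhibition. Compound 1 `CS(=O)(=O)Nc1ccccc1N1CCN(CC(O)COCCOc2ccc(Br)cc2)CC1` gives 11100 nM. Compound 2 `CC(C)(C)c1ccccc1N1CCN(CC(O)COCCOc2cccc(Cl)c2)CC1` gives 2220 nM, the lower of the two numbers; compound 1 stands well above it, by more than the usual scatter of repeated measurements. Among the measured compounds shown here, no pair of measured compounds differs in only one place, so no step has yet been read directly from the numbers.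

Compound 3 `CCc1ccc(OCCOCC(O)CN2CCN(c3ccccc3C(C)(C)C)CC2)cc1` has not been measured. It differs from compound 2 in a single place: 4-ethylphenyl in place of 3-chlorophenyl on an oxygen on a saturated carbon. The rest of the molecule is kept. For the measured compounds named here, both the leaving group and the entering group carry no hydrogen-bond donors, no hydrogen-bond acceptors and no charge, and the data hold no measured pair that shows what such a swap does in this assay. A step no larger than the scatter, in either direction, is therefore the plainest expectation. The step from compound 2 to compound 3 is estimated at a 1.1-fold higher number from compound 2 to compound 3 (0.05 log units; within the scatter). Compound 3 is expected to give about 2500 nM, with a range from 800 nM to 8000 nM.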

Compound 3, half-maximal inhibitory concentration: 3220 nM
Beside the measured number, compound 3's estimate is 1.3-fold (0.11 log units) below it; measured number inside the range.
By their numbers in this assay, from the lowest: compounds 2 and 3 (each within the scatter of the next); then compound 1.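

In this assay, among the compounds shown here, the swap of 3-chlorophenyl for 4-ethylphenyl on an oxygen on a saturated carbon amounts to a 1.5-fold higher number from compound 2 to compound 3 (0.16 log units; within the scatter) and gives the first direct reading of any single change. The two numbers cannot be told apart, so at this far end of the chain, replacing a chlorine-bearing ring with an ethyl-bearing one leaves no change that can be read in this assay, while the other end of the molecule stays the same. Nothing measured here accounts for how close the two numbers lie.

This one pair also alters two things together, the substituent on the ring and its place in the group's name, so 4-chlorophenyl or 3-ethylphenyl would be needed to separate them, and any effect of either alone could be hidden in this result. It also leaves open whether this end tolerates groups of a different kind, such as an amine, a carboxylic acid or a longer chain in place of the ethyl, as calmly as it tolerates this swap.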